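The compounds below may be only part of what the source reports. "The series", "measured", "known", "first", "only" and "open" are said of these compounds alone.

Among the compounds with values here, compound 2 `COc1cc(-c2nn(-c3cccc(NC(=O)c4ccc(Cl)c(C(F)(F)F)c4)c3)cc2-c2ccncc2)ccc1Cl` is the weaker of the two compounds measured so far in a functional assay on SN12C cells (Homo sapiens) for inhibition, read by sulforhodamine B assay, with a stated time of 48 h (a higher number here means a weaker inhibitor of growth, a lower number a stronger inhibitor of growth), where compound 2 gives 11200 nM. Its nearest neighbour, compound 1 `COc1cc(-c2nn(-c3cccc(NC(=O)Nc4cccc(C(F)(F)F)c4)c3)cc2-c2ccncc2)ccc1Cl`, gives 1400 nM in this assay; the change from compound 1 to compound 2 swaps (3-(trifluoromethyl)phenyl)amino for 4-chloro-3-(trifluoromethyl)phenyl on the carbonyl carbon and brings an 8.0-fold higher number from compound 1 to compound 2 (0.90 log units; beyond the scatter).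

Compound 3 `COc1cc(-c2nn(-c3cccc(NC(=O)c4ccccc4)c3)cc2-c2ccncc2)ccc1Cl` has not been measured. It differs from compound 2 in one place: phenyl in place of 4-chloro-3-(trifluoromethyl)phenyl on a carbonyl carbon. Within the data shown here, no measured step alters only this ring; the single step recorded, from compound 1 to compound 2, also changes the link to the carbonyl carbon, so it gives only a loose sense of how far a change at this end of the shared core can move the number in this assay. With nothing more direct to lean on, the expected step from compound 2 to compound 3 is a 1.3-fold higher number from compound 2 to compound 3 (0.13 log units; within the scatter), a mild drift toward a higher number with wide uncertainty. Compound 3 is therefore estimated at 15000 nM, with a likely range from 4000 nM to 60000 nM.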

Compound 3, concentration for 50% growth inhibition: 2950 nM
Beside the measured number, compound 3's estimate is 5.1-fold (0.71 log units) above it, outside the stated range (below it).
By their numbers in this assay, from the lowest: compound 1; then compound 3; then compound 2.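

Compound 2 and compound 3 differ only in the ring on the carbonyl carbon, and replacing 4-chloro-3-(trifluoromethyl)phenyl with plain phenyl gives a 3.8-fold lower number from compound 2 to compound 3 (0.58 log units; beyond the scatter) in this assay. This isolates an effect that the earlier step could not, as that step altered the link to the carbonyl carbon and the ring together: here, with the amide-type nitrogen kept, the ring alone moves the number, and the larger substituted ring does worse than the bare one. Compound 1, with (3-(trifluoromethyl)phenyl)amino on the carbonyl carbon, still has the lowest number of the three, as a 2.1-fold higher number from compound 1 to compound 3 (0.32 log units; beyond the scatter) shows, and nothing available explains either step.

As far as these compounds go, the chlorine and the trifluoromethyl leave together between compound 2 and compound 3, so it remains open whether one of them accounts for most of the step or both contribute. Also open, from the compounds shown here alone, is how the number in this assay would respond to a different group on this carbonyl carbon, such as a longer alkyl chain, or to an amine or a carboxylic acid on the phenyl ring.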